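Hydroxypiperidine replacing difluoropiperidine on the pyrimidine core

The compounds below may be only part of what the source reports. "The series", "measured", "known", "first", "only" and "open" are said of these compounds alone.

Of the compounds shown here, three sharing one core have been measured in an assay on a protein complex for activation of soluble guanylate cyclase (Homo sapiens), read by cGMP accumulation, in the presence of a further agent that is not named here; on this read-out lower numbers stand for an effect already at smaller amounts and higher numbers for an effect only at larger amounts of compound. Compound 1 `CNc1nc(-c2cc(-c3ccon3)n(Cc3ccccc3F)n2)ncc1F` gives 20 nM, compound 2 `Fc1ccccc1Cn1nc(-c2ncc(F)c(N3CCCCC3)n2)cc1-c1ccon1` gives 27 nM, and compound 3 `Fc1ccccc1Cn1nc(-c2ncc(F)c(N3CCC(F)(F)CC3)n2)cc1-c1ccon1` gives 250 nM. Compound 3 thus carries the highest number of the three: the step of a 9.3-fold higher number from compound 2 to compound 3 (0.97 log units; beyond the scatter) and the step of a 13-fold higher number from compound 1 to compound 3 (1.10 log units; beyond the scatter) both lie beyond the scatter, while the step of a 1.4-fold higher number from compound 1 to compound 2 (0.13 log units; within the scatter) does not.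

Compound 4 `OC1CCCN(c2nc(-c3cc(-c4ccon4)n(Cc4ccccc4F)n3)ncc2F)C1` has not yet been measured. The change is 3-hydroxypiperidin-1-yl in place of 4,4-difluoropiperidin-1-yl on an aromatic carbon. The step that bears most directly on it is a 9.3-fold higher number from compound 2 to compound 3 (0.97 log units; beyond the scatter), which shows that the difluorinated ring alone accounts for the higher number of compound 3 relative to the plain ring of compound 2. Removing the two fluorines while adding a hydroxyl is expected to bring the number back toward that of compound 2, though how far is uncertain on these data. The step expected here is a 4.2-fold lower number from compound 3 to compound 4 (0.62 log units; beyond the scatter). Compound 4 is therefore estimated at 60 nM, within a range of 20 nM to 200 nM.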

Compound 4, half-maximal effective concentration: 33 nM
The estimate for compound 4 lay 1.8-fold (0.26 log units) above the measured number, and the stated range covers the measured number.
By their numbers in this assay, from the lowest: compounds 1, 2 and 4 (each within the scatter of the next); then compound 3.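

In this assay, the 3-hydroxypiperidin-1-yl group does not share the higher number of the 4,4-difluoropiperidin-1-yl group (a 7.6-fold lower number from compound 3 to compound 4 (0.88 log units; beyond the scatter)). Adding hydroxy to the saturated ring of compound 2 leaves the number within the scatter (a 1.2-fold higher number from compound 2 to compound 4 (0.09 log units; within the scatter)), as does the change from the methylamino group of compound 1 (a 1.7-fold higher number from compound 1 to compound 4 (0.22 log units; within the scatter)), so at this position compound 3 alone stands apart among the four compounds. Nothing measured here explains why the 4,4-difluoropiperidin-1-yl group differs from the other groups.

From the compounds shown here alone, whether a 4-hydroxypiperidin-1-yl, 3-fluoropiperidin-1-yl or morpholin-4-yl group would stay with compounds 1, 2 and 4 or move toward compound 3 remains open. Going by these compounds, how the two mirror-image forms of the 3-hydroxypiperidin-1-yl group compare also remains open.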